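The source may hold more compounds than are shown below. What is called first, only, known or untested is meant among the compounds shown, and "the series" means these compounds.

The compounds here share one core, a thiazole-based scaffold carrying a hydrazone linker to a thioether-bearing acetyl group, and they were tested in a functional assay on C6 cells (Rattus norvegicus) for cytotoxicity, read by MTT assay, with a stated time of 24 h; a lower number here means a stronger inhibitor, a higher number a weaker inhibitor. Compound 2 `O=C(CSc1ncccn1)N/N=c1/scc(-c2ccc([N+](=O)[O-])cc2)n1-c1ccccc1` has no numerical result in this assay; for compound 2 the entry reads "not determined" (no result reported). Compound 3 `O=C(CSc1nnnn1-c1ccccc1)N/N=c1/scc(-c2ccc([N+](=O)[O-])cc2)n1-c1ccccc1` is in the same position, with compound 3 giving "not determined" (no result reported). Going by the values given here, the only numerical anchor is compound 1 `Cc1ccc(-c2cs/c(=N/NC(=O)CSc3nnnn3-c3ccccc3)n2-c2ccccc2)cc1`, for which compound 1 gives 14.7 ug/mL in this assay.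

The step of interest leads from compound 2 to compound 4 `Cc1ccc(-c2cs/c(=N/NC(=O)CSc3ncccn3)n2-c2ccccc2)cc1`. The change is methyl in place of nitro on an aromatic carbon. Among the compounds with values here, no measured pair shows this swap, so nothing can be said about the size or direction of the step from the data themselves. Compound 2 stands without a number, and no comparison can be drawn from it.

The estimate for compound 4 therefore rests only on compound 1, which shares the methylphenyl arm and differs in the heteroaryl part of the thioether; compound 4 is expected to fall near 15 ug/mL, within 6 ug/mL to 40 ug/mL, because compound 1 gives 14.7 ug/mL in this assay.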

Compound 4, half-maximal inhibitory concentration: 85 ug/mL
Compound 4: the middle estimate sits 5.7-fold (0.75 log units) below what was measured; measured number above the stated range.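

In this assay, going by these compounds alone, the group on the sulfur clearly counts: with the 4-methylphenyl arm the same in both compounds, pyrimidin-2-yl in place of 1-phenyl-1H-tetrazol-5-yl gives a 5.8-fold higher number from compound 1 to compound 4 (0.76 log units; beyond the scatter), a weakening beyond the usual scatter and the first real comparison in this small set. The step from 4-nitrophenyl to 4-methylphenyl cannot be read, as compound 2 has no number, so the high value of compound 4 says nothing about the effect of replacing nitro with methyl. Nothing measured here explains why the pyrimidin-2-yl compound is the weaker of the two.

On these data alone, it remains open whether the gap between the two sulfur groups would persist with nitro in place of methyl on the aromatic ring, a question that compound 2 and compound 3 could answer only with numbers of their own. Also open, as far as these compounds go, is how a methoxy group or a chlorine atom would read at that aromatic carbon, and how a plain phenyl ring or a longer alkyl chain would compare on the sulfur.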